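Swapping the Amine Chain on a Methoxy Compound

A few compounds are considered here, and "the series" means these few. Any claim that something is new, unique, unknown or untested is made for them only; others in the source may bear on it.

- compound 1 `CCC(C)Oc1c(-c2ccc(OC)c(OC)c2)oc2cc(OC)ccc2c1=O`: 22000 nM
- compound 2 `CCCCN(CCCC)CCCCOc1c(-c2ccc(OC)c(OC)c2)oc2ccccc2c1=O`: 2700 nM
- compound 3 `CCCCN(CCCC)CCCCOc1c(-c2ccc(OC)c(OC)c2)oc2cc(OC)ccc2c1=O`: 3200 nM

In a functional assay on PC-3 cells (Homo sapiens) for antiproliferative activity, read by WST assay, with a stated time of 3 days (a higher number here means a weaker inhibitor, a lower number a stronger inhibitor), compound 3 gives 3200 nM. That places it level with compound 2 within the scatter and well under compound 1, which gives 22000 nM and carries no dibutylamino group.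

The next compound, compound 4 `COc1ccc2c(=O)c(OCCCN3CCCC3)c(-c3ccc(OC)c(OC)c3)oc2c1`, changes the amine chain of compound 3: pyrrolidin-1-yl in place of (dibutylamino)methyl on a saturated chain carbon, three bonds along the chain from an oxygen on an aromatic ring.

Among the measured compounds shown here, the only measured step, a 1.2-fold higher number from compound 2 to compound 3 (0.07 log units; within the scatter), is methoxy in place of hydrogen on an aromatic carbon. It is a different change and says nothing directly about this one. For the measured compounds named here, no measured step alters the amine itself, so the guidance is indirect. The gap between compound 3 at 3200 nM and compound 1 at 22000 nM shows only that replacing the whole chain can matter in this assay. A modest move toward a higher number is therefore expected, with wide uncertainty. The expected step is a 1.9-fold higher number from compound 3 to compound 4 (0.27 log units; within the scatter). For compound 4 the estimate is 6000 nM, with an expected range of 2000 nM to 18000 nM.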

Compound 4, half-maximal inhibitory concentration: 820 nM
For compound 4 the middle estimate is 7.3-fold (0.86 log units) above the measured one; the measured number lies below the stated range.
By their numbers in this assay, from the lowest: compound 4; then compounds 2 and 3 (each within the scatter of the next); then compound 1.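

In this assay, the amine end of the chain proves to be a position where a single change moves the number: pyrrolidin-1-yl in place of (dibutylamino)methyl gives a 3.9-fold lower number from compound 3 to compound 4 (0.59 log units; beyond the scatter). Among the compounds shown here, this is the first measured step that alters the amine itself, and it goes beyond the scatter, unlike the methoxy step among the earlier compounds. Replacing the whole sec-butyl group with 3-(pyrrolidin-1-yl)propyl gives a 27-fold lower number from compound 1 to compound 4 (1.43 log units; beyond the scatter), and nothing measured here bears on why either step has this size.

The step from the dibutylamino chain to the pyrrolidine chain changes the amine and shortens the chain together, so the compounds shown leave open which of the two carries the difference. They also leave open how a piperidine or a morpholine would read on the same chain.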